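The source may hold more compounds than are shown below. What is called first, only, known or untested is meant among the compounds shown, and "the series" means these compounds.

Three close relatives sharing one core were tested in a functional assay on MCF7 cells (Homo sapiens) for antiproliferative activity, read by sulforhodamine B assay, with a stated time of 48 h; a higher number here means a weaker inhibitor, a lower number a stronger inhibitor. Compound 1 `CCc1ccccc1NS(=O)(=O)c1ccc(N2CCNC2=O)cc1` gives 350 nM. Compound 3 `O=C1NCCN1c1ccc(S(=O)(=O)Nc2ccc(Br)cc2)cc1` gives 240 nM, the lowest of the two plain numbers, with compound 1 nearest; the step of a 1.5-fold lower number from compound 1 to compound 3 (0.16 log units; within the scatter) lies within the scatter, so the two cannot be ranked. Compound 2 `COc1ccc(NS(=O)(=O)c2ccc(N3CCNC3=O)cc2)cc1` is recorded only as the limit > 1000 nM in this assay (the limit of > 1000 nM in this assay, at which 1 of the 3 values shown sits).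

Compound 4 `COc1cccc(NS(=O)(=O)c2ccc(N3CCNC3=O)cc2)c1` has not yet been measured; it differs from compound 3 by 3-methoxyphenyl in place of 4-bromophenyl on a sulfonamide nitrogen. Among the compounds with values here, two measured steps bear on this change. The step of an at least 4.1-fold lower number from compound 2 to compound 3 (0.61 log units; beyond the scatter) shows that a bromo group went with a much lower number than a methoxy group. The step of an at least 2.8-fold higher number from compound 1 to compound 2 (0.45 log units; beyond the scatter) likewise points toward a methoxy-bearing ring giving a higher number. Both steps concern a 4-methoxyphenyl, whereas compound 4 carries a 3-methoxyphenyl, so the exact size is uncertain, but the direction expected is upward, beyond the scatter, and possibly as far as a limit again.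

In this assay compound 4 is therefore expected to give about 800 nM, in a range from 350 nM to 2000 nM. That estimate means an expected step of a 3.3-fold higher number from compound 3 to compound 4 (0.52 log units; beyond the scatter).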

Compound 4, half-maximal inhibitory concentration: 120 nM
Compound 4: the middle estimate sits 6.7-fold (0.82 log units) above what was measured, outside the stated range (below it).
By their numbers in this assay, from the lowest: compounds 4, 3 and 1 (each within the scatter of the next, the first and the last beyond it). At a limit, above all of these: compound 2.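

The position of the methoxy group on the ring attached to the sulfonamide nitrogen matters a great deal in this assay, as shown by an at least 8.3-fold lower number from compound 2 to compound 4 (0.92 log units; beyond the scatter), so the poor showing of the 4-methoxyphenyl does not carry over to the 3-methoxyphenyl. As far as these compounds go, the size of that step stays open at one end, since compound 2 is recorded only at a limit: the limit of > 1000 nM in this assay, at which 1 of the 4 values shown sits. A methoxy group therefore does not go with a high number in every case: a 2.0-fold lower number from compound 3 to compound 4 (0.30 log units; within the scatter) leaves the 3-methoxyphenyl and the 4-bromophenyl unranked, while a 2.9-fold lower number from compound 1 to compound 4 (0.46 log units; beyond the scatter) separates the 3-methoxyphenyl from the 2-ethylphenyl.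

The compounds shown do not tell whether this low number is particular to the methoxy group, or whether a 3-bromophenyl, or an amine or a carboxylic acid in place of the methoxy group, would do as well on the sulfonamide nitrogen. They also leave open whether the same order would hold in other cell lines, as all four compounds are compared on MCF7 cells alone.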